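Ethyl for chloro on the core of compound 2

The source may report more compounds than this note shows. Statements on the series, on what has been measured and on what is new or still open speak of the compounds shown alone.

Measured compounds:
compound 1, `CN1CCN(c2nc3cc([N+](=O)[O-])ccc3o2)CC1`, 0.52
compound 2, `Cc1cc(Cl)c2oc(N3CCN(C)CC3)nc2c1`, 0.26
compound 3, `Cc1cccc2nc(N3CCN(C)CC3)oc12`, 0.58

In an assay on ileum (strain Hartley) with 5-hydroxytryptamine receptor 3A (Cavia porcellus) as the target (a higher number here means a larger maximal response, a lower number a smaller maximal response), compound 2 gives 0.26, the lowest of the three numbers. Its nearest neighbour is compound 1, whose 0.52 stands beyond the scatter above it, and compound 3, with 0.58, lies further off again, also beyond the scatter. Going by the values given here, no step between two measured compounds that differ in one place is known, so nothing direct is known about how a single change shifts the read-out.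

Compound 4, `CCc1cc(C)cc2nc(N3CCN(C)CC3)oc12`, has not yet been measured. It differs from compound 2 in one place:

ethyl in place of chloro on an aromatic carbon

The author expects the step from compound 2 to compound 4 to be upward and beyond the scatter, a number 0.19 higher from compound 2 to compound 4 (beyond the scatter), because compound 2 sits at 0.26 while the other two compounds, which carry no chloro, stand well above it. Among the compounds with values here, with no measured step of this kind to lean on, the range is kept wide. For compound 4 the estimated value in this assay is 0.45, between 0.25 and 0.65.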

Compound 4, intrinsic activity: the largest response reached, as a fraction of the reference agonist's: 0.26
Beside the measured number, compound 4's estimate is 0.19 above it, within the range that was stated.
By their numbers in this assay, from the lowest: compounds 2 and 4 (each within the scatter of the next); then compounds 1 and 3 (each within the scatter of the next).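

In this assay, the first step measured between two compounds that differ in one place shows no change at the digits printed from compound 2 to compound 4 (within the scatter), with ethyl in place of chloro on an aromatic carbon of the six-membered aromatic ring, ortho to a fused ring and meta to a fused ring. At this position, then, one chlorine can give way to the two carbons of an ethyl group with no visible effect on the maximal response, and the low number of compound 2 is not tied to chloro alone, since compound 4, which carries no chloro, gives 0.26. Nothing at hand offers an explanation for this match between the two groups.

On these data alone, what remains open is whether this position tolerates every group in the same way, or whether an amine, a carboxylic acid or a longer chain such as butyl would shift the maximal response beyond the scatter. A single step also leaves open whether ethyl in place of chloro would give the same result elsewhere on the shared core.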